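A few compounds are considered here, and "the series" means these few. Any claim that something is new, unique, unknown or untested is made for them only; others in the source may bear on it.

Of the compounds shown here, two have been measured in a functional assay for agonist activity at Bile acid receptor (Mus musculus), read by a luciferase reporter; a lower number here means that less compound is needed, a higher number that more compound is needed for the effect. Compound 1 `Cc1cc(OCc2c(-c3cc[nH]c(=O)c3Cl)noc2C(C)C)ccc1-c1ccc2c(C(=O)O)cn(C)c2c1` gives 7000 nM in this assay. Among the measured compounds shown here, its only neighbour, compound 2 `Cc1cc(OCc2c(-c3c(Cl)cn(C)c(=O)c3Cl)noc2C(C)C)ccc1-c1ccc2c(C(=O)O)cn(C)c2c1`, differs from it in one place and gives 11000 nM in this assay; the step between them is a 1.6-fold higher number from compound 1 to compound 2 (0.20 log units; within the scatter), so neither compound stands apart from the other.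

Compound 3 `Cc1cc(OCc2c(-c3ccn(C)c(=O)c3Cl)noc2C(C)C)ccc1-c1ccc2c(C(=O)O)cn(C)c2c1` is not yet measured. It arises from compound 1 by the change (methyl in place of hydrogen on an aromatic nitrogen), that is, a methyl in place of hydrogen on an aromatic nitrogen. For the measured compounds named here, the only measured step that bears on this is the one from compound 1 to compound 2, which brings in the same methyl together with a second chloro group and shifts the number by a 1.6-fold higher number from compound 1 to compound 2 (0.20 log units; within the scatter). Whether the methyl alone or the added chloro accounts for that shift cannot be separated with two compounds. For compound 3 the expected step is a 1.3-fold higher number from compound 1 to compound 3 (0.11 log units; within the scatter), a movement within the scatter. For compound 3 the estimate in this assay is 9000 nM, ranging from 4000 nM to 20000 nM.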

Compound 3, half-maximal effective concentration: 6000 nM
For compound 3 the middle estimate is 1.5-fold (0.18 log units) above the measured one; low and high end bracket the measured number.
By their numbers in this assay, from the lowest: compounds 3, 1 and 2 (each within the scatter of the next).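

In this assay, the methyl on the aromatic nitrogen can now be read on its own: it gives a 1.2-fold lower number from compound 1 to compound 3 (0.07 log units; within the scatter), so the nitrogen carries either hydrogen or methyl with no step beyond the scatter. The second change, hydrogen in place of chloro on an aromatic carbon, can be read separately as well and gives a 1.8-fold lower number from compound 2 to compound 3 (0.26 log units; within the scatter), which also stays within the scatter, so neither part of the earlier combined step stands out alone in these compounds. Nothing available explains why these numbers lie so close together.

Methyl is the only group seen on this nitrogen, so it remains open whether a longer chain such as ethyl, or a chain ending in an amine or a carboxylic acid, would move the number beyond the scatter. Going by these compounds, all three compounds also share the rest of their structure, so it is unknown whether the methyl would give so small a step on a different core.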